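The compounds below may be only part of what the source reports. "The series", "measured", "known", "first", "only" and "open" are said of these compounds alone.

Measured compounds:
- compound 1, `Cc1ccc(OCC(=O)N(Cc2cccs2)C2CCCCC2)cc1`: 40000 nM
- compound 2, `CCN(Cc1cccs1)C(=O)COc1ccc(F)cc1`: 422 nM

Both values come from an assay on HEK293 cells for agonist activity at transient receptor potential cation channel subfamily M member 8 (Homo sapiens), read by fluorescence and calcium flux, with a stated time of 15 min; on this read-out lower numbers stand for an effect already at smaller amounts and higher numbers for an effect only at larger amounts of compound. Of the two numbers, compound 1 has the higher one; compound 2 stands at a lower number, and the gap between them is beyond the usual scatter. Compound 2 differs from compound 1 in more than one place, so its values alone tell nothing about any single change.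

Compound 3, `Cc1ccc(OCC(=O)N(Cc2cccs2)c2nccs2)cc1`, is not yet measured. It keeps the core of compound 1 and differs from it in one place: 1,3-thiazol-2-yl in place of cyclohexyl on an amide-type nitrogen. Among the compounds with values here, no pair of measured compounds shows this change alone, so its effect has to be guessed. In this assay the step from compound 1 to compound 3 is expected to give a moderately lower number, a 2.7-fold lower number from compound 1 to compound 3 (0.43 log units; beyond the scatter), though a change no larger than the scatter is also plausible. The estimate for compound 3 in this assay is 15000 nM, with a likely range from 3000 nM to 60000 nM.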

Compound 3, half-maximal effective concentration: 2240 nM
The estimate for compound 3 lay 6.7-fold (0.83 log units) above the measured number; the whole stated range lies above it.
By their numbers in this assay, from the lowest: compound 2; then compound 3; then compound 1.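

In this assay, within the data shown here, the nitrogen position turns out to be highly sensitive: putting 1,3-thiazol-2-yl in place of cyclohexyl gives an 18-fold lower number from compound 1 to compound 3 (1.25 log units; beyond the scatter) as a large step, the first view of one change on its own, since compound 1 and compound 2 differ in more than one place. The six-membered non-aromatic ring of carbon only is therefore not needed at this nitrogen for an effect in this series, and a five-membered aromatic ring with 2 hetero atoms is accepted there and goes with an effect at much smaller amounts of compound. Nothing available here accounts for the size of this step, so it stands as an observation without an explanation.

This single swap alters ring size, aromatic character and the hetero atoms all at once, so the compounds shown cannot say which of these differences matters. A phenyl ring or a cyclopentyl ring on the same nitrogen would begin to separate them, with phenyl keeping an aromatic ring without hetero atoms and cyclopentyl keeping the five-membered size without aromatic character.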